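Alkyl extension on the shared core: compound 2 to compound 3

A few compounds are considered here, and "the series" means these few. Any claim that something is new, unique, unknown or untested is made for them only; others in the source may bear on it.

Compound 2 `Cc1c(C(=O)N[C@@H](C)c2ccc(C(=O)O)cc2)nnn1Cc1ccc(C(F)(F)F)cc1` carries a methyl on an aromatic carbon of the shared core. In a functional assay on CHO cells for antagonist activity at prostaglandin E2 receptor EP4 subtype (Homo sapiens), read by calcium flux, with a stated time of 15 min (on this read-out lower numbers stand for stronger inhibition and higher numbers for weaker inhibition), compound 2 gives > 10000 nM, which is a limit of the assay and not a number. Compound 1 `C[C@H](NC(=O)c1cn(Cc2ccc(C(F)(F)F)cc2)nn1)c1ccc(C(=O)O)cc1` lacks that methyl. In this assay compound 1 gives > 10000 nM, again a limit rather than a number. The step that the two limits leave unreadable from compound 1 to compound 2 therefore cannot be read in size. Compound 3 `CCCc1c(C(=O)N[C@@H](C)c2ccc(C(=O)O)cc2)nnn1Cc1ccc(C(F)(F)F)cc1` differs from compound 2 by ethyl in place of hydrogen on a saturated chain carbon bound to an aromatic carbon. Among the compounds with values here, the only measured step, hydrogen to methyl, is unreadable, and both values shown sit at the limit of > 10000 nM in this assay, at which 2 of the 2 values shown sit, so no direction beyond the scatter can be set. Compound 3 is expected to remain at or near the limit, and the step that the limit leaves unreadable from compound 2 to compound 3 is the expected outcome. Compound 3 is estimated at 20000 nM, in the range 4000 nM to 100000 nM, and is most likely to be reported again as a limit.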

Compound 3, half-maximal inhibitory concentration: > 10000 nM
Compound 3 ended at the assay's limit; the forecaster's own chance of this, stated with the estimate: 85%; the middle value is on the limit's open side.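

No new step can be read among compound 1, compound 2 and compound 3 in this assay, as each value is a limit and not a number: the limit of > 10000 nM in this assay, at which 3 of the 3 values shown sit.

The compounds shown leave open how far these three differ from one another, and which change to the shared core would give a readable value.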